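The compounds below may be only part of what the source reports. "The series", "measured", "known", "first", "only" and "open" are said of these compounds alone.

Measured compounds:
compound 1 `OC[C@H]1O[C@@H](n2cnc3c(COc4ccccc4)ncnc32)[C@H](O)[C@@H]1O` — > 100000 nM
compound 2 `OCCSCc1ncnc2c1ncn2[C@@H]1O[C@H](CO)[C@@H](O)[C@H]1O` — > 100000 nM
compound 3 `OC[C@H]1O[C@@H](n2cnc3c(CS)ncnc32)C[C@@H]1O` — 41000 nM

In a functional assay on Huh-7 cells (Homo sapiens) for cytotoxicity, read by MTT assay, with a stated time of 3 days (a higher number here means that more compound is tolerated, a lower number that less compound is tolerated), compound 1 gives only a limit, > 100000 nM. Compound 2 likewise gives only a limit in this assay, > 100000 nM. Compound 3, which carries a sulfanyl group on the saturated chain carbon and lacks one hydroxyl on its sugar, gives 41000 nM in this assay. Within the data shown here, the single step that differs in one place, a step that the two limits leave unreadable from compound 1 to compound 2, is therefore not readable in size, and compound 1 stands at the limit with one further value of the three.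

The untested compound 4 `CSCc1ncnc2c1ncn2[C@@H]1O[C@H](CO)[C@@H](O)[C@H]1O` differs from compound 1 as follows: methylsulfanyl in place of phenoxy on a saturated chain carbon bound to an aromatic carbon. Among the measured compounds shown here, the measured step that bears on it is the one from compound 1 to compound 2, where a sulfur-linked group also replaced the phenoxy; its size is hidden (the limit of > 100000 nM in this assay, at which 2 of the 3 values shown sit). For the measured compounds named here, no measured step shows a readable change in this assay, so no shift beyond the scatter is expected, and the new compound is expected to sit near the limit as compound 1 does. Compound 4 is estimated at 100000 nM, between 40000 nM and 300000 nM, an expected step of a number no higher from compound 1 to compound 4 (the limit leaves the size open).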

Compound 4, half-maximal cytotoxic concentration: > 100000 nM
Compound 4: a limit, no number; the forecaster's own chance of this, stated with the estimate: 60%; the middle value lies on the limit itself.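

In this assay compound 4 gives only a limit, > 100000 nM. No step from compound 1 or compound 2 to compound 4 can be read, because each of the three values is a limit: the limit of > 100000 nM in this assay, at which 3 of the 4 values shown sit.

The compounds shown leave open how far compound 1, compound 2 and compound 4 differ in this assay, if they differ at all.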